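What cyano might do where ethyl gave only a limit

The source may report more compounds than this note shows. Statements on the series, on what has been measured and on what is new or still open speak of the compounds shown alone.

In a functional assay on HCT-116 cells (Homo sapiens) for cytotoxicity, read by scintillation counting and thymidine incorporation, with a stated time of 72 h (on this read-out higher numbers stand for weaker inhibition and lower numbers for stronger inhibition), compound 3 `CCC=C(c1cc(OC)cc(OC)c1)c1ccc(OC)c(OC)c1` gives > 10000 nM, which is a limit of the assay and not a number. Compound 1 `COc1cc(OC)cc(C(=CC(N)=O)c2ccc(OC)c(OC)c2)c1` gives > 10000 nM in this assay, and this too is a limit. Compound 3 therefore sits at the limit of > 10000 nM in this assay, at which 2 of the 3 values shown sit, with no exact position on the scale.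

Compound 4 `COc1cc(OC)cc(C(=CC#N)c2ccc(OC)c(OC)c2)c1` is the next structure to be tested. It is compound 3 with cyano in place of ethyl on a double-bonded chain carbon bound to a double-bonded chain carbon.

Within the data shown here, the one measured step at this place is a step that the two limits leave unreadable from compound 1 to compound 3, so it offers no size to carry over. The better guide is compound 2 `CCOc1cc(C(=CC#N)c2cc(OC)cc(OC)c2)ccc1OC`, which carries cyano at the same place and gives 34 nM in this assay. Among the three measured compounds, only compound 2 gives a number rather than a limit. Compound 2 is not identical to compound 4 elsewhere on the shared core, so the expectation stays broad.

A large move toward stronger inhibition is therefore expected, and the estimated step is an at least 330-fold lower number from compound 3 to compound 4 (2.52 log units; beyond the scatter). For compound 4 the expected value is 30 nM, with an estimated range from 6 nM to 300 nM.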

Compound 4, half-maximal inhibitory concentration: 18 nM
Compound 4: the middle estimate sits 1.7-fold (0.22 log units) above what was measured; low and high end bracket the measured number.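

In this assay, cyano in place of ethyl on this double-bonded chain carbon gives an at least 550-fold lower number from compound 3 to compound 4 (2.74 log units; beyond the scatter), and cyano in place of carbamoyl at the same place gives an at least 550-fold lower number from compound 1 to compound 4 (2.74 log units; beyond the scatter), so this position now has a readable lower bound on a step, which the unreadable step between carbamoyl and ethyl could not provide. Compound 1 and compound 3 each stand at a limit of the assay and not at a number: the limit of > 10000 nM in this assay, at which 2 of the 4 values shown sit. Elsewhere on the shared core, hydrogen in place of methyl on a saturated chain carbon bound to an oxygen on an aromatic ring gives a 1.9-fold lower number from compound 2 to compound 4 (0.28 log units; within the scatter), so the two cannot be told apart, and cyano goes with a low number in both.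

On these data alone, only cyano, carbamoyl and ethyl appear at this place, so it remains open whether a carboxylic acid, an aldehyde or an aminomethyl group there would give a number or a limit. How far the ethyl and carbamoyl compounds truly lie from the cyano compounds also stays open, as the shown values give only a lower bound on those steps.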